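From 2-oxopyrrolidin-1-yl to cyano in a cytotoxicity test

A few compounds are considered here, and "the series" means these few. Any claim that something is new, unique, unknown or untested is made for them only; others in the source may bear on it.

Compound 3 `Cc1cc(N2CCCC2=O)cn2c(CSCCc3ccccc3)cnc12` is reported in an ADME assay on HEL cells (Homo sapiens) for cytotoxicity, with a stated time of 3 days (on this read-out higher numbers stand for lower toxicity in this test and lower numbers for higher toxicity in this test), only as a limit, > 100 ug/mL. Compound 1 `Cc1cc(-c2ccsc2)cn2c(CSCc3ccccc3)cnc12` gives 4 ug/mL in this assay. Compound 2 `Cc1cc(-c2ccoc2)cn2c(CSCCc3ccccc3)cnc12` is likewise reported only as a limit, > 4 ug/mL. Going by the values given here, the step that the two limits leave unreadable from compound 2 to compound 3 is therefore unreadable in size, and it is the only measured step that touches compound 3. Compound 4 `Cc1cc(C#N)cn2c(CSCCc3ccccc3)cnc12` differs from compound 3 by cyano in place of 2-oxopyrrolidin-1-yl on an aromatic carbon. Among the compounds with values here, none of the measured compounds carries a cyano group, so no step speaks to this change directly. Because compound 3 rests at a limit > 100 ug/mL, the step of a number no higher from compound 3 to compound 4 (the limit leaves the size open) is expected to stay small. Compound 4 is estimated at about 100 ug/mL, with a range from 30 ug/mL to 300 ug/mL.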

Compound 4, minimum cytotoxic concentration: 20 ug/mL
Beside the measured number, compound 4's estimate is 5.0-fold (0.70 log units) above it, outside the stated range (below it).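

In this assay, going by these compounds alone, the aromatic carbon carrying these groups proves able to shift the read-out by a measurable amount: cyano in place of 2-oxopyrrolidin-1-yl gives an at least 5.0-fold lower number from compound 3 to compound 4 (0.69 log units; beyond the scatter), the first readable step at this position. For compound 3, > 100 ug/mL is a limit. Nothing measured here accounts for the change.

The steps from compound 2 cannot be read. On these data alone, whether an amine or a carboxylic acid on this aromatic carbon would give a number nearer that of compound 3 or compound 4 stays open.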